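Inverting one stereocentre in a low-clearance series

The source may hold more compounds than are shown below. What is called first, only, known or untested is meant among the compounds shown, and "the series" means these compounds.

In an ADME assay on microsomes from liver (Homo sapiens) for metabolic stability, read by LC-MS, using NADPH, with stated times of 10 min and 30 min (on this read-out higher numbers stand for fast clearance and lower numbers for slow clearance), compound 1 (`CC(=O)N[C@@H]1CCCc2c1cncc2N1CCc2cc(Cl)ccc2C1=O`) gives 4.3 mL/min/kg. Compound 2 (`CCC(=O)N[C@@H]1CCCc2c1cncc2N1C(=O)c2ccc(Cl)cc2[C@@H]1C`) gives < 3.5 mL/min/kg, which is a limit of the assay. Compound 3 (`CC(=O)N[C@@H]1CCCc2c1cncc2N1C(=O)c2ccc(Cl)cc2[C@@H]1C`) gives < 3.5 mL/min/kg, also a limit and not a number, so it stands at the limit of < 3.5 mL/min/kg in this assay, at which 2 of the 3 values shown sit. Compound 4 (`CC(=O)N[C@@H]1CCCc2c1cncc2N1C(=O)c2ccc(Cl)cc2[C@H]1C`) departs from compound 3 in one respect: the two compounds have the same atoms and bonds and differ only in configuration as drawn: 1 of 2 stereo elements differ; a stereocentre at a saturated ring carbon is drawn S in compound 3 and R in compound 4. Going by the values given here, the only measured step, a step that the two limits leave unreadable from compound 2 to compound 3, is a change of another kind and offers no size to carry over. No step beyond the scatter is therefore expected, and no direction can be favoured. The expected outcome is a number no lower from compound 3 to compound 4 (the limit leaves the size open). For compound 4, the estimated clearance is 3.5 mL/min/kg, within an expected range of 2 mL/min/kg to 6.5 mL/min/kg.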

Compound 4, clearance: < 3.5 mL/min/kg
Compound 4 gave a limit, no number; the forecaster's own chance of this, stated with the estimate: 50%; the middle value lies on the limit itself.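

Compound 3 and compound 4 both give a limit of the assay and not a number, and no step can be read between them. The compounds shown leave open whether clearance differs between these two drawn configurations.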